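Working notes: from compound 2 to compound 4

The source may report more compounds than this note shows. Statements on the series, on what has been measured and on what is new or still open speak of the compounds shown alone.

Measured so far in a functional assay on KB cells (Homo sapiens) for cytotoxicity; on this read-out lower numbers stand for stronger inhibition and higher numbers for weaker inhibition
- compound 1 `C/C=C/C(=O)OC1=CC(=O)c2ccccc2C1=O` gives 64200 nM
- compound 2 `O=C(OC1=CC(=O)c2ccccc2C1=O)c1ccccc1` gives 36900 nM
- compound 3 `COc1ccc2c(c1)C(=O)C=CC2=O` gives 33900 nM

Compound 2 at 36900 nM lies within the scatter of both other measured compounds, so these three values support no ranking. The next comparison is with compound 4 `CC(=O)OC1=CC(=O)c2ccccc2C1=O`, which carries methyl in place of phenyl on a carbonyl carbon, the counted difference being methyl in place of phenyl on a carbonyl carbon in full.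

Within the data shown here, one measured step bears on this place, with phenyl in place of prop-1-en-1-yl on a carbonyl carbon. That step is a 1.7-fold lower number from compound 1 to compound 2 (0.24 log units; within the scatter) and so gives no sign of a real effect from exchanging the group. Compound 3 lacks this carbonyl side chain, and its value of 33900 nM still falls among the others in this assay without separation from compound 2. Among the measured compounds shown here, one step is thin evidence, and no measured compound has methyl here.

No change beyond the scatter is therefore expected in this assay, the estimated step being a 1.2-fold higher number from compound 2 to compound 4 (0.09 log units; within the scatter) as a working figure. For compound 4 the expected value is 45000 nM with an estimated range of 20000 nM to 100000 nM for the coming measurement.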

Compound 4, half-maximal inhibitory concentration: 38800 nM
Compound 4: the middle estimate sits 1.2-fold (0.06 log units) above what was measured; the range from low to high includes it.
By their numbers in this assay, from the lowest: compounds 3, 2, 4 and 1 (each within the scatter of the next).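

In this assay, methyl in place of phenyl on a carbonyl carbon gives a 1.1-fold higher number from compound 2 to compound 4 (0.02 log units; within the scatter), so the loss of the six-membered aromatic ring, with 6 heavy atoms replaced by 1, produces no separable change at this place. Methyl in place of prop-1-en-1-yl gives a 1.7-fold lower number from compound 1 to compound 4 (0.22 log units; within the scatter), which is also within the scatter, so the three groups compared on this carbonyl carbon, phenyl, prop-1-en-1-yl and methyl, are not told apart by this read-out, and the earlier single step now has support from a group with no ring and only one carbon. No measured evidence is available to explain this lack of separation.

From the compounds shown here alone, these three groups are all hydrocarbon groups with no hydrogen-bond donors or acceptors by the count given for phenyl and methyl, so it remains open whether an amine, a carboxylic acid or a longer chain on this carbonyl carbon would give a step beyond the scatter. The compounds shown also leave open whether any change elsewhere on the shared core, with this carbonyl side chain held constant, would separate from these values.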